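This account rests on a few compounds, and the source may have more. Where it says the series, first, only, none or still open, it means among the compounds named here.

The study compared three aryl sulfonamides that share one core and then turned to a fourth. Compound 1 `Cc1ccc(S(=O)(=O)Nc2ccc(-c3nc4ccccc4o3)cc2)cc1` carries a 4-methylphenyl group on the sulfonyl sulfur. In an assay on isolated protein for inhibition of malate dehydrogenase, mitochondrial (Sus scrofa), with stated times of 45 min and 30 min (on this read-out lower numbers stand for stronger inhibition and higher numbers for weaker inhibition), compound 1 gives only a limit of the assay, > 63000 nM. Compound 3 `O=S(=O)(Nc1ccc(-c2nc3ccccc3o2)cc1)c1cccc(O)c1` swaps that group for 3-hydroxyphenyl, and in this assay compound 3 likewise returns a limit, > 63000 nM. Compound 2 `Cc1ccc(S(=O)(=O)Nc2ccc3oc(-c4ccccc4)nc3c2)cc1` keeps the 4-methylphenyl sulfonyl but attaches the sulfonamide nitrogen at a different point of the core; in this assay compound 2 also reaches only a limit, > 63000 nM. So compound 2 stands where the other two stand, at the limit of > 63000 nM in this assay, at which 3 of the 3 values shown sit, and nothing in the numbers separates it from them.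

Among the compounds with values here, the single one-place step that was measured, a step that the two limits leave unreadable from compound 1 to compound 3, runs between two limits and its size cannot be read.

Compound 4 `O=S(=O)(Nc1ccc2oc(-c3ccccc3)nc2c1)c1ccc(Cl)cc1` differs from compound 2 by chloro in place of methyl on an aromatic carbon, para to a large group. Within the data shown here, no measured step gives a direction or a size for such a change, and every value shown is a limit. Compound 4 is therefore expected to sit at or beyond the limit as well, estimated at 100000 nM with a range from 30000 nM to 300000 nM. The expected step from compound 2 to compound 4 is a step that the limit leaves unreadable from compound 2 to compound 4, which is not readable beyond the scatter.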

Compound 4, half-maximal inhibitory concentration: > 63000 nM
Compound 4: no number, only a limit; the forecaster's own chance of this, stated with the estimate: 85%; the middle value is on the limit's open side.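

Compound 4, like compound 2, returns only a limit in this assay, so no step between them can be read, and the swap of methyl for chloro has no readable size: the limit of > 63000 nM in this assay, at which 4 of the 4 values shown sit.

The compounds shown leave open whether any change to the shared core gives a real number in this assay, and in which direction such changes act.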